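Nitro-position swap on a nitroimidazole piperazine pair

The source may hold more compounds than are shown below. What is called first, only, known or untested is meant among the compounds shown, and "the series" means these compounds.

The study compares four compounds built from a 2-methyl-nitroimidazole on a saturated chain carrying a hydroxyl. Compound 1 `Cc1ncc([N+](=O)[O-])n1CC(O)CSC(=S)N1CCN(c2cccc(Cl)c2)CC1` and compound 3 `Cc1nc([N+](=O)[O-])cn1CC(O)CSC(=S)N1CCN(c2cccc(Cl)c2)CC1` share one core; compound 2 `Cc1ncc([N+](=O)[O-])n1CC(O)CN1CCN(c2cccc(Cl)c2Cl)CC1` and compound 4 `Cc1nc([N+](=O)[O-])cn1CC(O)CN1CCN(c2cccc(Cl)c2Cl)CC1` share another, and the difference between the two cores is not broken down here. In a toxicity assay on HeLa cells (Homo sapiens) for cytotoxicity, read by MTT assay, with a stated time of 24 h (on this read-out higher numbers stand for weaker inhibition and lower numbers for stronger inhibition), compound 1 gives 1080000 nM and compound 3 gives 1740000 nM. The step from the first to the second, (2-methyl-4-nitro-1H-imidazol-1-yl in place of 2-methyl-5-nitro-1H-imidazol-1-yl on a saturated chain carbon, two bonds along the chain from an oxygen on a saturated carbon), amounts to a 1.6-fold higher number from compound 1 to compound 3 (0.21 log units; within the scatter). Compound 2 reaches only a limit in this assay, namely > 5000000 nM. Compound 4 is not yet measured; it carries the same change as compound 3 does against compound 1, (2-methyl-4-nitro-1H-imidazol-1-yl in place of 2-methyl-5-nitro-1H-imidazol-1-yl on a saturated chain carbon, two bonds along the chain from an oxygen on a saturated carbon), on the same place of the chain. Since compound 2 already sits at the limit of > 5000000 nM in this assay, at which 1 of the 3 values shown sits, and the same change moved compound 1 to compound 3 by an amount within the scatter, compound 4 is expected to move by a step that the limit leaves unreadable from compound 2 to compound 4 from compound 2. The estimate for compound 4 in this assay is 6000000 nM, with a range from 2500000 nM to 15000000 nM, and a limit rather than a number is the likelier outcome.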

Compound 4, half-maximal inhibitory concentration: 3620000 nM
Beside the measured number, compound 4's estimate is 1.7-fold (0.22 log units) above it; the measured number falls inside the stated range.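

In this assay, 2-methyl-4-nitro-1H-imidazol-1-yl in place of 2-methyl-5-nitro-1H-imidazol-1-yl on the second core gives an at least 1.3-fold lower number from compound 2 to compound 4 (0.14 log units; that floor lies within the scatter). The value of compound 2, > 5000000 nM, is a limit and not a number. Neither core shows a step that is certain to lie beyond the scatter, yet this does not establish that the change carries over unaltered from one core to the other: the same change on two cores in this assay, a 1.6-fold higher number (0.21 log units; within the scatter) from compound 1 to compound 3 and an at least 1.3-fold lower number (0.14 log units; that floor lies within the scatter) from compound 2 to compound 4; the limit leaves it open whether they differ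

The compounds shown leave open how the same change would read if the chain were a longer chain, or if an amine or a carboxylic acid stood in place of the hydroxyl. Within the data shown here, they also leave open what separates the two cores themselves, as these differ in more than one place and no single step links them.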